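Swapping methoxy for amino on a shared core

The source may report more compounds than this note shows. Statements on the series, on what has been measured and on what is new or still open speak of the compounds shown alone.

Values measured so far in an ADME assay (liver) for metabolic stability, with Liver microsome (Rattus norvegicus) as the target, using microsomes (a lower number here means slower removal, a higher number faster removal of the compound), are these:
- compound 1 `O=C(O)c1csc(-n2nc(-c3ccccc3)c3ccc(F)cc32)n1` gives 337 mL/min/kg
- compound 2 `O=C(O)c1csc(-n2nc(-c3ccccc3)c3ccc(O)cc32)n1` gives 522 mL/min/kg
- compound 3 `COc1ccc2c(-c3ccccc3)nn(-c3nc(C(=O)O)cs3)c2c1` gives 196 mL/min/kg

Compound 3 stands at the low end of these numbers. The gap to compound 2 is clear, with a 2.7-fold lower number from compound 2 to compound 3 (0.43 log units; beyond the scatter) as the measured step. The gap to compound 1 is not, with a 1.7-fold lower number from compound 1 to compound 3 (0.24 log units; within the scatter) as the measured step.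

Compound 4 `Nc1ccc2c(-c3ccccc3)nn(-c3nc(C(=O)O)cs3)c2c1` has not been measured yet. It has amino in place of methoxy on an aromatic carbon, and the full difference is amino in place of methoxy on an aromatic carbon as counted from the two structures.

For the measured compounds named here, no compound with amino at this place has a measured number, so the guidance is indirect. The other swaps here are small: a 1.5-fold higher number from compound 1 to compound 2 (0.19 log units; within the scatter) is one, and the largest, a 2.7-fold lower number from compound 2 to compound 3 (0.43 log units; beyond the scatter) again, is only modest. Like hydroxy in compound 2 at 522 mL/min/kg, amino is a hydrogen-bond donor, which methoxy is not. That points to a small rise in this assay rather than a fall, though this is a weak guide.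

The expected step is a 1.5-fold higher number from compound 3 to compound 4 (0.18 log units; within the scatter) and would not stand clearly beyond the scatter. The estimated value for compound 4 is 300 mL/min/kg with 140 mL/min/kg to 620 mL/min/kg as the expected range.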

Compound 4, clearance: 208 mL/min/kg
Beside the measured number, compound 4's estimate is 1.4-fold (0.16 log units) above it; the measured number falls inside the stated range.
By their numbers in this assay, from the lowest: compounds 3, 4, 1 and 2 (each within the scatter of the next, the first and the last beyond it).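

At this place on the shared core, amino and methoxy cannot be told apart in this assay, with a 1.1-fold higher number from compound 3 to compound 4 (0.03 log units; within the scatter). Amino and hydroxy are both hydrogen-bond donors, yet they do separate, with a 2.5-fold lower number from compound 2 to compound 4 (0.40 log units; beyond the scatter), so among these compounds the presence of a donor at this carbon does not by itself bring the high number seen for hydroxy. The comparison with fluoro gives a 1.6-fold lower number from compound 1 to compound 4 (0.21 log units; within the scatter), which means that amino matches methoxy in this respect as well: each stands clearly apart from hydroxy, but neither stands clearly apart from fluoro.

On these data alone, it remains open whether larger or substituted nitrogen groups at this place, such as dimethylamino or acetamido, or a longer chain on the oxygen, such as ethoxy, would stay within this narrow span of numbers or leave it. The compounds shown also come with no other measurement that could explain why amino and hydroxy part here while amino and methoxy do not.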